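The source may hold more compounds than are shown below. What is called first, only, known or untested is meant among the compounds shown, and "the series" means these compounds.

Working notes on the series. All four compounds share the core of compound 1 `CC(=O)OC/C1=C/C[C@](C)(CCC=C(C)C)/C=C/[C@@H](OC(=O)C=C(C)C)[C@](C)(O)/C=C/C1=O`; compound 2 `CC(C)=CCC[C@]1(C)/C=C/[C@@H](OC(=O)C=C(C)C)[C@](C)(O)/C=C/C(=O)/C(C(=O)O)=C\C1`, compound 3 `CC(C)=CCC[C@]1(C)/C=C/[C@@H](OC(=O)C=C(C)C)[C@](C)(O)/C=C/C(=O)/C(CN2CCCC2)=C\C1` and the unmeasured compound 4 `CC(C)=CCC[C@]1(C)/C=C/[C@@H](OC(=O)C=C(C)C)[C@](C)(O)/C=C/C(=O)/C(Cn2cc(CO)nn2)=C\C1` differ from it only at one double-bonded ring carbon. In a functional assay on SW480 cells (Homo sapiens) for antiproliferative activity, read by MTT assay, with a stated time of 48 h (on this read-out higher numbers stand for weaker inhibition and lower numbers for stronger inhibition), compound 1 gives 2950 nM and compound 3 gives 310 nM. Compound 2 gives only a limit of the assay, > 10000 nM in this assay. On the numbers shown compound 2 therefore stands at the limit of > 10000 nM in this assay, at which 1 of the 3 values shown sits, without a number of its own.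

The measured steps at this position: an at least 3.3-fold higher number from compound 1 to compound 2 (0.53 log units; beyond the scatter); an at least 32-fold lower number from compound 2 to compound 3 (1.50 log units; beyond the scatter); a 9.5-fold lower number from compound 1 to compound 3 (0.98 log units; beyond the scatter). Both neutral and basic replacements of the carboxy group, the acetoxymethyl of compound 1 and the (pyrrolidin-1-yl)methyl of compound 3, move the number down from compound 2, the basic one by far the most.

The step to compound 4 is (4-(hydroxymethyl)-1H-1,2,3-triazol-1-yl)methyl in place of carboxy on a double-bonded ring carbon

The entering group is neutral, as in compound 1, so the step from compound 2 to compound 4 is expected to resemble the step from compound 2 to compound 1 more than that to compound 3, that is a fall clearly beyond the scatter, short of the fall seen with compound 3. Compound 4 is therefore estimated at 1500 nM in this assay, within 300 nM to 8000 nM, which corresponds to the expected step of an at least 6.6-fold lower number from compound 2 to compound 4 (0.82 log units; beyond the scatter).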

Compound 4, half-maximal inhibitory concentration: 2870 nM
Beside the measured number, compound 4's estimate is 1.9-fold (0.28 log units) below it; the measured number falls inside the stated range.
By their numbers in this assay, from the lowest: compound 3; then compounds 4 and 1 (each within the scatter of the next). At a limit, above all of these: compound 2.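

In this assay, the entry of (4-(hydroxymethyl)-1H-1,2,3-triazol-1-yl)methyl gives a second group with no net charge at this double-bonded ring carbon, and with 4-(hydroxymethyl)-1H-1,2,3-triazol-1-yl in place of acetoxy the result is a 1.0-fold lower number from compound 1 to compound 4 (0.01 log units; within the scatter) so that a five-membered aromatic ring and an ester side chain cannot be told apart here. Against this pair pyrrolidin-1-yl stands alone, with a 9.3-fold higher number from compound 3 to compound 4 (0.97 log units; beyond the scatter) as the step away from it, so among the groups shown on this saturated chain carbon only compound 3 departs from the level of compound 1 and compound 4. Against the carboxy group the step is an at least 3.4-fold lower number from compound 2 to compound 4 (0.54 log units; beyond the scatter) and is read only as a bound because compound 2 stands at a limit of the assay: the limit of > 10000 nM in this assay, at which 1 of the 4 values shown sits.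

From the compounds shown here alone, whether the low number of compound 3 belongs to pyrrolidin-1-yl alone or extends to other amines on the same saturated chain carbon, such as piperidin-1-yl, morpholin-4-yl or dimethylamino, stays open. Also open, going by these compounds, is what the hydroxymethyl on the triazole adds, which a 4-methyl-1H-1,2,3-triazol-1-yl group would address.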